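The source may report more compounds than this note shows. Statements on the series, on what has been measured and on what is new or still open speak of the compounds shown alone.

Compounds measured so far:
Compound 1 `O=C1/C(=C/c2cccnc2)CN(S(=O)(=O)c2ccccc2)C/C1=C\c1ccccc1F`: 8210 nM
Compound 2 `O=C1/C(=C/c2cccnc2)CN(S(=O)(=O)c2ccc([N+](=O)[O-])cc2)C/C1=C\c1ccccc1F`: 12800 nM

In a functional assay on HepG2 cells (Homo sapiens) for cytotoxicity, read by MTT assay, with a stated time of 24 h (on this read-out lower numbers stand for stronger inhibition and higher numbers for weaker inhibition), only these two compounds have been measured, so compound 1 has a single neighbour on the scale. Its value of 8210 nM lies within the scatter of compound 2 at 12800 nM, and neither can be ranked above the other.

The next compound to be measured is compound 3 `O=C1/C(=C/c2ccncc2)CN(S(=O)(=O)c2ccccc2)C/C1=C\c1ccccc1F`. It differs from compound 1 as follows: pyridin-4-yl in place of pyridin-3-yl on a double-bonded chain carbon bound to a double-bonded ring carbon. In words, pyridin-4-yl stands in place of pyridin-3-yl on a double-bonded chain carbon bound to a double-bonded ring carbon.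

Among the compounds with values here, no measured step covers this change. The only one available is a 1.6-fold higher number from compound 1 to compound 2 (0.19 log units; within the scatter), and it is a nitro in place of hydrogen on an aromatic carbon, at a different place in the molecule. Within the data shown here, it bears on the question only indirectly, showing that the one change tried so far on the core of compound 1 stayed within the scatter. With nothing to suggest a direction, no shift beyond the scatter is expected in this assay.

The expected step is a 1.0-fold higher number from compound 1 to compound 3 (0.02 log units; within the scatter). The estimated value for compound 3 is 8500 nM, with an expected range from 3500 nM to 20000 nM.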

Compound 3, half-maximal inhibitory concentration: 5800 nM
Compound 3: middle estimate off by 1.5-fold (0.17 log units), on the high side; the measured number falls inside the stated range.
By their numbers in this assay, from the lowest: compounds 3, 1 and 2 (each within the scatter of the next, the first and the last beyond it).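

In this assay, exchanging pyridin-3-yl for pyridin-4-yl on a double-bonded chain carbon bound to a double-bonded ring carbon gives a 1.4-fold lower number from compound 1 to compound 3 (0.15 log units; within the scatter). Within the data shown here, the only earlier step, a 1.6-fold higher number from compound 1 to compound 2 (0.19 log units; within the scatter), concerned a nitro group at a different place in the molecule, so this is the first reading at this position, and it does not separate the two pyridine isomers, which have the same atoms joined differently. Nothing available offers an explanation for this result.

The compounds shown leave open whether any group at this position would move the number beyond the scatter, since only two pyridine isomers are compared there; a plain phenyl, pyridin-2-yl or a pyridine ring carrying a dimethylamino group could give a different answer. They also leave open whether a nitro group in place of hydrogen on the aromatic carbon, as in compound 2, would give a similarly small step when combined with pyridin-4-yl rather than pyridin-3-yl.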